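Extending the alkyl chain: from compound 2 to compound 4

A few compounds are considered here, and "the series" means these few. Any claim that something is new, unique, unknown or untested is made for them only; others in the source may bear on it.

Measured in an assay on microsomes from liver for inhibition of sterol O-acyltransferase 1 (Rattus norvegicus); a lower number here means a stronger inhibitor, a higher number a weaker inhibitor:
compound 1, `CCCCCCCCC(c1ccccc1)S(=O)(=O)NC(=O)Nc1c(C(C)C)cccc1C(C)C`, gives 9200 nM;
compound 2, `CCCCCCCCCCS(=O)(=O)NC(=O)Nc1c(C(C)C)cccc1C(C)C`, gives 13600 nM;
compound 3, `CCCCCCCCCCCCCC(C)S(=O)(=O)NC(=O)Nc1c(C(C)C)cccc1C(C)C`, gives 830 nM.

Compound 2 has the highest number of the three. Compound 1 lies within the scatter of it, so no order between the two can be read. Compound 3 gives a lower number, beyond the scatter. Compound 4, `CCCCCCCCCCCCCCCCS(=O)(=O)NC(=O)Nc1c(C(C)C)cccc1C(C)C`, is not yet measured; it differs from compound 2 by hexyl in place of hydrogen on a saturated chain carbon, ten or more bonds along the chain from a sulfonyl sulfur. Within the data shown here, no pair differing in one place has been measured, so no step size is known directly. Compound 3 carries the longest chain of the measured three and gives the lowest number, so a lower number is expected for compound 4. For compound 4 the estimate in this assay is 1500 nM, with a range of 400 nM to 6000 nM. The expected step is a 9.1-fold lower number from compound 2 to compound 4 (0.96 log units; beyond the scatter), beyond the scatter.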

Compound 4, half-maximal inhibitory concentration: 1270 nM
For compound 4 the middle estimate is 1.2-fold (0.07 log units) above the measured one; measured number inside the range.
By their numbers in this assay, from the lowest: compounds 3 and 4 (each within the scatter of the next); then compounds 1 and 2 (each within the scatter of the next).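

In this assay, hexyl in place of hydrogen on a saturated chain carbon, ten or more bonds along the chain from a sulfonyl sulfur, gives an 11-fold lower number from compound 2 to compound 4 (1.03 log units; beyond the scatter). Among these compounds, this is the only step read between compounds that differ in one place, and it shows that extending the chain alone, with the rest of the structure unchanged, produces a large change. No measurement shown accounts for this step.
Going by these compounds, whether a still longer chain would lower the number further remains open. So does the effect of an amine or a carboxylic acid on this chain.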